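From Bromo to Phenyl in a Small Cytotoxicity Series

The source may hold more compounds than are shown below. What is called first, only, known or untested is meant among the compounds shown, and "the series" means these compounds.

Of the compounds shown here, three that share one core have been measured in a functional assay on HL-60 cells (Homo sapiens) for cytotoxicity, read by CCK-8 assay, with a stated time of 24 h; on this read-out higher numbers stand for weaker inhibition and lower numbers for stronger inhibition. Compound 1 `C=CC(=O)N1C(=O)CC(c2ccc(C(F)(F)F)cc2)Sc2ccccc21` gives 106000 nM, and compound 2 `C=CC(=O)N1C(=O)CC(C)Sc2ccccc21` gives 199000 nM. Compound 3 `C=CC(=O)N1C(=O)CC(c2ccc(Br)cc2)Sc2ccccc21` gives 126000 nM, a value within the usual scatter of both of the others, so the data do not rank it clearly against either one.

The next compound, compound 4 `C=CC(=O)N1C(=O)CC(c2ccc(-c3ccccc3)cc2)Sc2ccccc21`, has not yet been measured. It comes from compound 3 by one change, phenyl in place of bromo on an aromatic carbon. The group enters para to a large group, and it is clearly bigger than the bromo it replaces.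

Within the data shown here, two measured steps bear on this. Among the measured compounds shown here, the closest precedent also changes a group on an aromatic carbon, bromo in place of trifluoromethyl, and it gives a 1.2-fold higher number from compound 1 to compound 3 (0.08 log units; within the scatter). A much larger swap, 4-bromophenyl in place of methyl on a saturated ring carbon, gives a 1.6-fold lower number from compound 2 to compound 3 (0.20 log units; within the scatter). Neither step leaves the scatter, although neither involves a new aromatic ring at this position, so the comparison is imperfect.

No change beyond the scatter is therefore expected, and the estimated step is a 1.1-fold lower number from compound 3 to compound 4 (0.06 log units; within the scatter). The estimate for compound 4 is 110000 nM, with an expected range from 55000 nM to 220000 nM.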

Compound 4, half-maximal inhibitory concentration: 118000 nM
Beside the measured number, compound 4's estimate is 1.1-fold (0.03 log units) below it; the range from low to high includes it.
By their numbers in this assay, from the lowest: compounds 1, 4, 3 and 2 (each within the scatter of the next).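

In this assay, among these compounds, a whole new aromatic ring on this aromatic carbon, with six carbon atoms where a single bromine stood, gives a 1.1-fold lower number from compound 3 to compound 4 (0.03 log units; within the scatter) and so leaves the read-out within the scatter, something the earlier compounds could not show because none of them carried a second ring here. Set against the trifluoromethyl group, the phenyl group gives a 1.1-fold higher number from compound 1 to compound 4 (0.05 log units; within the scatter) in the same assay, so trifluoromethyl, bromo and phenyl cannot be told apart at this position, even though they differ clearly in the atoms they bring. Nothing available explains why these three groups read alike in this cell assay.

As far as these compounds go, all three groups are free of hydrogen-bond donors and acceptors and carry no net charge, so it remains open whether an amine or a carboxylic acid on this aromatic carbon would move the number beyond the scatter. From the compounds shown here alone, it is equally open whether a longer chain, or a plain hydrogen with no group at all, would do so, and therefore whether this position can influence the read-out in any way.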